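Thiophene-fused series: alkyne pyridone to chlorobenzyl swap

The source may hold more compounds than are shown below. What is called first, only, known or untested is meant among the compounds shown, and "the series" means these compounds.

Compound 2 `C[C@H](NC(=O)c1c(C#Cc2ccc(=O)[nH]c2)sc2c1CCOC2)c1ccc(C(=O)O)cc1` sits at the weak end of the three numbers in hand: in a functional assay on CHO/Galpha16 cells for antagonist activity at prostaglandin E2 receptor EP4 subtype (Homo sapiens), read by calcium flux, with a stated time of 15 min (a lower number here means a stronger inhibitor, a higher number a weaker inhibitor), compound 2 gives 642 nM, the highest of the set. Compound 1 `COc1cccc(C#Cc2sc3c(c2C(=O)N[C@@H](C)c2ccc(C(=O)O)cc2)CCOC3)c1` gives 12.4 nM and compound 3 `O=C(NCC1CCC(C(=O)O)CC1)c1c(Cc2ccc(F)cc2)sc2c1CCOC2` gives 30.3 nM. Compound 4 `C[C@H](NC(=O)c1c(Cc2cccc(Cl)c2)sc2c1CCOC2)c1ccc(C(=O)O)cc1` is not yet measured. The change from compound 2 to compound 4 is a group of 8 heavy atoms (7 carbon, 1 chlorine; one six-membered aromatic ring of carbon only) in place of a group of 9 heavy atoms (7 carbon, 1 nitrogen, 1 oxygen; one six-membered aromatic ring with 1 hetero atom), on an aromatic carbon.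

Among the compounds with values here, the one measured step that bears on this change is a 52-fold higher number from compound 1 to compound 2 (1.71 log units; beyond the scatter): replacing the carbon-only aromatic ring on the triple-bonded carbon with the ring holding one hetero atom costs a great deal. Compound 4 goes the other way, back to a carbon-only aromatic ring, now carried on a one-carbon link as in compound 3, whose value with a different acid part is close to that of compound 1. A large step downward is therefore expected, a 36-fold lower number from compound 2 to compound 4 (1.55 log units; beyond the scatter), landing near compounds 1 and 3. The estimate for compound 4 is 18 nM, expected to fall between 5 nM and 60 nM.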

Compound 4, half-maximal inhibitory concentration: 3.2 nM
Estimate against measurement, compound 4: 5.6-fold (0.75 log units) above, and the stated range ends above it.
By their numbers in this assay, from the lowest: compound 4; then compound 1; then compound 3; then compound 2.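

In this assay, 3-chlorobenzyl on the aromatic carbon next to the ring sulfur gives a 200-fold lower number from compound 2 to compound 4 (2.30 log units; beyond the scatter), more than recovering the loss seen with the ring holding one hetero atom in compound 2. With the rest of the molecule unchanged, 3-chlorobenzyl also gives a 3.9-fold lower number from compound 1 to compound 4 (0.59 log units; beyond the scatter), so a triple bond at this position is not needed for a low number among these compounds. No supporting data accompany these values to explain the differences between the groups.

Both steps change the link and the aromatic ring together, so a 3-methoxybenzyl or 2-(3-chlorophenyl)ethynyl group would be needed to separate those two changes. On these data alone, whether 3-chlorobenzyl gives a similar result with the acid part of compound 3 also remains open.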